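Hydroxymethyl in place of ethoxycarbonyl on compound 1

The source may hold more compounds than are shown below. What is called first, only, known or untested is meant among the compounds shown, and "the series" means these compounds.

Measured so far:
compound 1, `CCOC(=O)c1c(C)coc1-c1ccc2c(CC)cccc2c1OC`: gives 3.9 ug/mL in a functional assay on ZR-75-1 cells (Homo sapiens) for cytotoxicity, read by MTT assay, with a stated time of 72 h; on this read-out lower numbers stand for an effect already at smaller amounts and higher numbers for an effect only at larger amounts of compound
compound 2, `CCc1cccc2c(OC)c(-c3occ(C)c3C(=O)On3nnc4ccccc43)ccc12`: compound 2 reaches only the limit > 10 ug/mL in this assay

Compound 1 is the only one of the two with a number in this assay; compound 2 sits at the limit, as recorded in the limit of > 10 ug/mL in this assay, at which 1 of the 2 values shown sits. Within the data shown here, the one measured step, an at least 2.5-fold higher number from compound 1 to compound 2 (0.40 log units; beyond the scatter), replaces the ethyl of the ester with a larger ring-bearing group on the oxygen next to the carbonyl and costs at least modestly.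

Compound 3, `CCc1cccc2c(OC)c(-c3occ(C)c3CO)ccc12`, carries hydroxymethyl in place of ethoxycarbonyl on an aromatic carbon. Among the measured compounds shown here, this removes the ester altogether rather than enlarging it, so the measured step bears on it only loosely; it shows that the one change tried at the ester lowered the effect. A somewhat weaker effect than compound 1 is expected, of modest size, and a limit cannot be ruled out. Compound 3 is therefore estimated at 6.5 ug/mL in this assay, between 2.5 ug/mL and 15 ug/mL, meaning an expected step of a 1.7-fold higher number from compound 1 to compound 3 (0.22 log units; within the scatter).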

Compound 3, concentration for half-maximal effect: > 10 ug/mL
Compound 3: only a limit was reported (the forecaster's own chance of this, stated with the estimate: 30%); at least 1.5-fold (0.18 log units) between middle value and limit.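

In this assay, hydroxymethyl in place of ethoxycarbonyl gives an at least 2.5-fold higher number from compound 1 to compound 3 (0.40 log units; beyond the scatter). Compound 3 reaches only a limit, > 10 ug/mL, so this step has a lower bound and no exact size. Among these compounds, the earlier step enlarged the group on the ester oxygen and kept the carbonyl, whereas this change removes the ester and leaves a smaller group on the same aromatic carbon; with a weaker effect in both directions, the ethoxycarbonyl of compound 1 remains the only group at this position that gives a number in this assay.

Compound 2 and compound 3 cannot be ordered against each other because both sit at the same limit: the limit of > 10 ug/mL in this assay, at which 2 of the 3 values shown sit. Still open, on these data alone, is whether a carboxylic acid, a methyl ester or a primary amide on this aromatic carbon would keep an effect like that of compound 1, at 3.9 ug/mL, and so whether the carbonyl, the ethyl group or the whole ethoxycarbonyl goes with the measured effect.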